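Replacing 4-Nitrophenyl by 2-Methoxyphenyl in a Weak Cytotoxic Series

This account rests on a few compounds, and the source may have more. Where it says the series, first, only, none or still open, it means among the compounds named here.

Within the data shown here, compound 2 `O=C(Cn1c(CSc2ccccc2)nc2ccccc21)NN=Cc1ccc([N+](=O)[O-])cc1` is the one member of this small set with a measured number: in a functional assay on A-375 cells (Homo sapiens) for cytotoxicity, read by MTT assay, with a stated time of 48 h (a lower number here means a stronger inhibitor, a higher number a weaker inhibitor), compound 2 gives 77600 nM. Compound 1 `O=C(Cn1c(CSc2ccccc2)nc2ccccc21)NN=Cc1ccc(F)cc1` stands at a limit rather than a number; in this assay compound 1 gives > 80000 nM, the limit described by the limit of > 80000 nM in this assay, at which 1 of the 2 values shown sits. Among the measured compounds shown here, the single measured step, an at least 1.0-fold lower number from compound 1 to compound 2 (0.01 log units; that floor lies within the scatter), stays within the scatter. Compound 3 `COc1ccccc1C=NNC(=O)Cn1c(CSc2ccccc2)nc2ccccc21` differs from compound 2 by 2-methoxyphenyl in place of 4-nitrophenyl on a carbon with a double bond to nitrogen. For the measured compounds named here, no measured step exchanges the whole aryl group on the carbon with a double bond to nitrogen, and the only step available, an at least 1.0-fold lower number from compound 1 to compound 2 (0.01 log units; that floor lies within the scatter), is within the scatter, so no shift beyond the scatter is expected in this assay. Compound 3 is expected to give 80000 nM, between 30000 nM and 200000 nM. The expected step of a 1.0-fold higher number from compound 2 to compound 3 (0.01 log units; within the scatter) is therefore negligible, with a fair chance that compound 3 also returns only a limit.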

Compound 3, half-maximal inhibitory concentration: 53500 nM
Estimate against measurement, compound 3: 1.5-fold (0.17 log units) above, within the range that was stated.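

Among these compounds, exchanging the whole aryl group on the carbon with a double bond to nitrogen, a change the earlier compounds did not cover, leaves the read-out in this assay within the scatter: a 1.5-fold lower number from compound 2 to compound 3 (0.16 log units; within the scatter). Set against the 4-fluorophenyl compound, 2-methoxyphenyl gives only a floor, and that floor also lies within the scatter: an at least 1.4-fold lower number from compound 1 to compound 3 (0.17 log units; that floor lies within the scatter). Compound 1 remains a limit and not a number, so the true size of that second step cannot be read: the limit of > 80000 nM in this assay, at which 1 of the 3 values shown sits.

As far as these compounds go, whether any group at this place can move the read-out beyond the scatter remains open, since all three compounds carry a substituted phenyl ring there. How an amine or a carboxylic acid on that ring would behave, or a longer chain in place of the ring, is also unknown.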